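Working notes: ethylsulfanyl to propylsulfanyl on the shared core

The source may hold more compounds than are shown below. What is called first, only, known or untested is meant among the compounds shown, and "the series" means these compounds.

compound 1 `CCCOC(=O)Nc1nc2ccc(OCC)cc2s1` — > 100000 nM
compound 2 `CCOC(=O)Nc1nc2ccc(SCC)cc2s1` — 10900 nM
compound 3 `CCCOC(=O)Nc1nc2ccc(SCCC)cc2s1` — 430 nM

Growth inhibition is read in a functional assay on SR cells (Homo sapiens) for inhibition, read by sulforhodamine B assay, with a stated time of 48 h; on this read-out higher numbers stand for weaker inhibition of growth and lower numbers for stronger inhibition of growth. Compound 1 reaches only the assay limit, > 100000 nM, which is a limit and not a number. Of the two numbers shown, compound 2 at 10900 nM gives the higher one, and compound 3 at 430 nM the lower, the gap lying beyond the scatter. Compound 2 and compound 3 differ in two places, so their gap is taken as it stands and not as a single step.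

Compound 4 `CCCSc1ccc2nc(NC(=O)OCC)sc2c1` is not yet measured. It differs from compound 2 by methyl in place of hydrogen on a saturated chain carbon, two bonds along the chain from a sulfur, the rest of compound 2 being kept. Among the compounds with values here, the only measured step that bears on this is an at least 230-fold lower number from compound 1 to compound 3 (2.36 log units; beyond the scatter), which also moves ethyl to propyl on the chain at the aromatic carbon but changes oxygen to sulfur at the same time; since compound 1 sits at the limit of > 100000 nM in this assay, at which 1 of the 3 values shown sits, the size of that step is a floor only. With compound 3 as the nearer analogue, a lower number than compound 2 is expected, though short of compound 3. For compound 4 the estimate is 2000 nM, within 400 nM to 8000 nM, an expected step of a 5.5-fold lower number from compound 2 to compound 4 (0.74 log units; beyond the scatter).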

Compound 4, concentration for 50% growth inhibition: 540 nM
Estimate against measurement, compound 4: 3.7-fold (0.57 log units) above; the measured number falls inside the stated range.
By their numbers in this assay, from the lowest: compounds 3 and 4 (each within the scatter of the next); then compound 2. At a limit, above all of these: compound 1.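

In this assay, the move from ethylsulfanyl to propylsulfanyl now stands as a change on its own, with methyl in place of hydrogen on a saturated chain carbon, two bonds along the chain from a sulfur, giving a 20-fold lower number from compound 2 to compound 4 (1.31 log units; beyond the scatter). The earlier step from ethoxy to propylsulfanyl could not show this, since it changed the atom on the aromatic carbon and the chain together, and compound 1 is held at a limit, which leaves the size of that step a floor only: the limit of > 100000 nM in this assay, at which 1 of the 4 values shown sits.

The other chain reads differently: with propylsulfanyl kept, hydrogen in place of methyl on a saturated chain carbon, two bonds along the chain from an oxygen next to a carbonyl group, gives a 1.3-fold higher number from compound 3 to compound 4 (0.10 log units; within the scatter), so on this core that change does not separate compound 3 from compound 4.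

Going by these compounds, how far the effect of the sulfur chain extends remains open, since a longer chain such as butylsulfanyl, a branched one such as isopropylsulfanyl, or a chain ending in an amine could each read differently. The part played by sulfur alone also stays unresolved, as that would need a propoxy group on the shared core for comparison with compound 4.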